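The compounds below may be only part of what the source reports. "The series", "measured", "known", "first", "only" and "open" are said of these compounds alone.

Working notes on the series. All compounds share a core carrying a substituent on a saturated chain carbon bound to a sulfur. Compound 1 `Cc1cc(Nc2cc(-c3ccccc3)[nH]n2)n2nc(SCc3c(Cl)cccc3Cl)nc2n1` has 2,6-dichlorophenyl there, and in a functional assay on MGC-803 cells (Homo sapiens) for inhibition, read by MTT assay, with a stated time of 72 h (on this read-out lower numbers stand for stronger inhibition and higher numbers for weaker inhibition), compound 1 gives 5280 nM. Compound 2 `Cc1cc(Nc2cc(-c3ccccc3)[nH]n2)n2nc(SCc3ccc(Cl)cc3)nc2n1` has 4-chlorophenyl, and in this assay compound 2 gives 3950 nM. Compound 3 `Cc1cc(Nc2cc(-c3ccccc3)[nH]n2)n2nc(SCc3cccc4ccccc34)nc2n1` has naphthalen-1-yl, and in this assay compound 3 gives 3120 nM. Compound 3 holds the lowest of the three numbers, but the steps towards it, a 1.7-fold lower number from compound 1 to compound 3 (0.23 log units; within the scatter) and a 1.3-fold lower number from compound 2 to compound 3 (0.10 log units; within the scatter), like a 1.3-fold lower number from compound 1 to compound 2 (0.13 log units; within the scatter), all fall within the scatter; the three aromatic substituents are not separated by these data.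

Compound 4 `CCCSc1nc2nc(C)cc(Nc3cc(-c4ccccc4)[nH]n3)n2n1` is the next step: ethyl in place of naphthalen-1-yl on a saturated chain carbon bound to a sulfur. Within the data shown here, no measured step exchanges an aromatic ring for a chain at this position, so the three measured steps bear on it only indirectly: they show the position tolerating three different aromatic groups without a change beyond the scatter. Among the measured compounds shown here, removing both aromatic rings is a larger change than any of those, and a modest rise in the number is expected, a 1.9-fold higher number from compound 3 to compound 4 (0.28 log units; within the scatter), though a flat result would also be consistent with the series so far. Compound 4 is estimated at 6000 nM, with a range from 2500 nM to 15000 nM.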

Compound 4, half-maximal inhibitory concentration: 12600 nM
For compound 4 the middle estimate is 2.1-fold (0.32 log units) below the measured one; the range from low to high includes it.
By their numbers in this assay, from the lowest: compounds 3, 2 and 1 (each within the scatter of the next); then compound 4.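

In this assay the position proves not indifferent to every change: ethyl on a saturated chain carbon bound to a sulfur, in place of an aromatic group, gives a step beyond the scatter from each aromatic compound, with a 4.0-fold higher number from compound 3 to compound 4 (0.61 log units; beyond the scatter) and with a 3.2-fold higher number from compound 2 to compound 4 (0.50 log units; beyond the scatter) and also with a 2.4-fold higher number from compound 1 to compound 4 (0.38 log units; beyond the scatter) on the same kind of exchange. The three aromatic substituents, which could not be separated from one another, therefore stand together on the side of lower numbers, with compound 4 alone on the side of weaker inhibition, though each step is only modest. Nothing available here accounts for this difference.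

Compound 4 is a single chain example, so the result cannot say whether the aromatic ring itself matters or whether the loss of heavy atoms in going from (naphthalen-1-yl)methyl to propyl is enough to give the step. As far as these compounds go, a longer chain such as hexyl, an unsubstituted phenyl, and an amine or a carboxylic acid carried on the chain would each bear on that question, and their place relative to these four compounds stays open.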